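Ester in place of amide at the carbonyl of compound 3

The source may report more compounds than this note shows. Statements on the series, on what has been measured and on what is new or still open speak of the compounds shown alone.

Of the compounds shown here, three sharing one core have been measured in a functional assay on L1210 cells (Mus musculus) for inhibition; a lower number here means a stronger inhibitor, a higher number a weaker inhibitor. Compound 1 `C#CCOC(=O)c1ccc2[nH]c(NC(=O)OC)nc2c1` gives 10000 nM, compound 2 `COC(=O)Nc1nc2cc(C(=O)NCC(C)(C)C)ccc2[nH]1` gives 8600 nM, and compound 3 `COC(=O)Nc1nc2cc(C(=O)NC(C)C)ccc2[nH]1` gives 2000 nM. Compound 3 stands lowest of the three: the move a 5.0-fold lower number from compound 1 to compound 3 (0.70 log units; beyond the scatter) and the move a 4.3-fold lower number from compound 2 to compound 3 (0.63 log units; beyond the scatter) both lie beyond the scatter, whereas the move a 1.2-fold lower number from compound 1 to compound 2 (0.07 log units; within the scatter) does not.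

Compound 4 `COC(=O)Nc1nc2cc(C(=O)OCC3CC3)ccc2[nH]1` differs from compound 3 in one place: cyclopropylmethoxy in place of isopropylamino on a carbonyl carbon. The change carries the carbonyl back from an amide, as in compound 3, to an ester, as in compound 1. The step that bears most directly on it is a 5.0-fold lower number from compound 1 to compound 3 (0.70 log units; beyond the scatter), which shows that the one ester measured so far sits well above the isopropylamide. No ester other than compound 1 has been measured, so how a cyclopropylmethoxy ester compares with a propargyloxy ester is not known from these data.

On that basis compound 4 is expected to move in this assay by a 3.0-fold higher number from compound 3 to compound 4 (0.48 log units; beyond the scatter), a modest rise back toward the number of compound 1. The estimate for compound 4 is 6000 nM, with a range from 2000 nM to 20000 nM.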

Compound 4, half-maximal inhibitory concentration: 6900 nM
For compound 4 the middle estimate is 1.2-fold (0.06 log units) below the measured one, within the range that was stated.
By their numbers in this assay, from the lowest: compound 3; then compounds 4, 2 and 1 (each within the scatter of the next).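

In this assay, the second ester on this carbonyl carbon falls in with the first, a 1.4-fold lower number from compound 1 to compound 4 (0.16 log units; within the scatter), so replacing ethynyl with cyclopropyl on the ester chain produces no change that can be read beyond the scatter. Compound 3 stands apart from the ester compound 4 by a 3.5-fold higher number from compound 3 to compound 4 (0.54 log units; beyond the scatter), but the neopentylamide shows that an amide at this position does not by itself give the lower number: a 1.2-fold lower number from compound 2 to compound 4 (0.10 log units; within the scatter) leaves that amide and the ester within the scatter, so compound 2 goes against any rule that amides stand below esters here. The gain at this position therefore rests on the isopropylamide of compound 3 alone, and nothing available explains these steps.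

On these data alone, what remains open is how a cyclopropylmethylamino group would stand on this carbonyl carbon, since it would set the amide and ester links side by side with the same cyclopropylmethyl group. Also open, as far as these compounds go, is whether a smaller amide such as ethylamino, or a carboxylic acid at this place, would fall nearer compound 3 or nearer the other three compounds.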